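This account rests on a few compounds, and the source may have more. Where it says the series, first, only, none or still open, it means among the compounds named here.

Series notes. Potency is followed in an assay for inhibition of Polyunsaturated fatty acid 5-lipoxygenase (Homo sapiens), read by HPLC, with stated times of 15 min and 10 min; on this read-out lower numbers stand for stronger inhibition and higher numbers for weaker inhibition. Compound 2 `CC(C#Cc1cccc(C(=O)NCCC(c2ccccc2)c2ccc(OC(F)(F)F)cc2)c1)N(O)C(N)=O` gives 110 nM in this assay. Compound 3 `CC(C#Cc1cccc(C(=O)NCCC(c2ccccc2)c2ccc(F)cc2)c1)N(O)C(N)=O` gives 160 nM in this assay. Compound 1 `CNc1nc(C)nc(N[C@H]2CCC[C@@H](C(=O)NCc3ccc(C#N)cc3C(F)(F)F)C2)n1` belongs to a different core; for compound 1 this assay records "not determined" (no result reported). Of the two numbers in hand compound 3 carries the higher one, but the gap to compound 2 is small, a 1.5-fold higher number from compound 2 to compound 3 (0.16 log units; within the scatter), so the two lie within the scatter of each other and no ranking is drawn.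

Compound 4 `CC(C#Cc1cccc(C(=O)NCCC(c2ccccc2)c2ccccc2)c1)N(O)C(N)=O` differs from compound 3 in one place: hydrogen in place of fluoro on an aromatic carbon. Going by the values given here, only one measured step touches this position, the step from compound 2 to compound 3, which stayed within the scatter. Because a 1.5-fold higher number from compound 2 to compound 3 (0.16 log units; within the scatter) was that small, the step in this assay from compound 3 to compound 4 is expected to remain small as well, if anything leaning to a higher number, and is estimated as a 1.3-fold higher number from compound 3 to compound 4 (0.10 log units; within the scatter). For compound 4 the value in this assay is expected near 200 nM, with a range from 80 nM to 500 nM.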

Compound 4, half-maximal inhibitory concentration: 300 nM
Beside the measured number, compound 4's estimate is 1.5-fold (0.18 log units) below it, within the range that was stated.
By their numbers in this assay, from the lowest: compounds 2, 3 and 4 (each within the scatter of the next, the first and the last beyond it).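

Going from 4-fluorophenyl to phenyl gives a 1.9-fold higher number from compound 3 to compound 4 (0.27 log units; within the scatter) in this assay, so fluoro and hydrogen at this position are not told apart. Going by these compounds alone, the position does respond in one comparison: hydrogen in place of trifluoromethoxy gives a 2.7-fold higher number from compound 2 to compound 4 (0.44 log units; beyond the scatter), the first step here to clear the scatter, although it remains modest, while compound 3 lies within the scatter of both compound 2 and compound 4. No measured evidence is available to account for this result.

The compounds shown leave open whether an amine or a carboxylic acid at this place would produce a larger step than any seen so far. They also leave open whether chloro or methoxy would track with fluoro or with trifluoromethoxy.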